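Alkyl growth on the ring amine: outlook for compound 4

The source may hold more compounds than are shown below. What is called first, only, known or untested is meant among the compounds shown, and "the series" means these compounds.

Measured in an assay on HEK293 cells for displacement of a labelled ligand from 5-hydroxytryptamine receptor 7 (Rattus norvegicus), with a stated time of 60 min; on this read-out lower numbers stand for stronger inhibition and higher numbers for weaker inhibition:
compound 1 `Fc1ccc(-c2cn(Cc3ccccc3)c3c2CNCC3)cc1` gives 45 nM
compound 2 `CN1CCc2c(c(-c3ccc(Cl)cc3)cn2Cc2ccccc2)C1` gives 36 nM
compound 3 `CCN1CCc2c(c(-c3ccc(Cl)cc3)cn2Cc2ccccc2)C1` gives 250 nM

Compound 3 stands at the highest of the three numbers in this assay; compound 1 sits nearest to it and compound 2 furthest, both lower and both beyond the scatter. Compound 1 and compound 2 differ in more than one place, so their two values are reported as they are, without a step between them.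

Compound 4 `CC(C)N1CCc2c(c(-c3ccc(Cl)cc3)cn2Cc2ccccc2)C1` differs from compound 3 by methyl in place of hydrogen on a saturated chain carbon bound to an amine nitrogen in a ring and a saturated chain carbon; read one bond further out, ethyl becomes isopropyl. Among the measured compounds shown here, the one measured step that bears on this is a 6.9-fold higher number from compound 2 to compound 3 (0.84 log units; beyond the scatter), where the same kind of addition at the chain attached to the ring amine nitrogen weakened binding by a modest amount. For the measured compounds named here, a second methyl at this chain is expected to move the number in the same direction, beyond the scatter, though with only one precedent the size is uncertain; it is estimated as a 2.4-fold higher number from compound 3 to compound 4 (0.38 log units; beyond the scatter). Compound 4 is therefore expected to give about 600 nM in this assay, within a range of 250 nM to 1500 nM.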

Compound 4, inhibition constant: 370 nM
For compound 4 the middle estimate is 1.6-fold (0.21 log units) above the measured one; the range from low to high includes it.
By their numbers in this assay, from the lowest: compounds 2 and 1 (each within the scatter of the next); then compounds 3 and 4 (each within the scatter of the next).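

Ethyl to isopropyl reads as a 1.5-fold higher number from compound 3 to compound 4 (0.17 log units; within the scatter) in this assay, so compound 3 and compound 4 cannot be told apart on this read-out. At this position, then, the second methyl does not repeat the first, which gave a 6.9-fold higher number from compound 2 to compound 3 (0.84 log units; beyond the scatter) and lay beyond the scatter. Read as a single change on the amine nitrogen in the ring, isopropyl in place of methyl gives a 10-fold higher number from compound 2 to compound 4 (1.01 log units; beyond the scatter), so the large part of this step sits in the first addition. Nothing at hand explains why the two additions read differently.

On these data alone, how a longer chain such as propyl, or a benzyl group, on the ring amine nitrogen would read remains open. Compound 1 and compound 2 differ in more than one place, so the effect of the methyl on that nitrogen cannot be read from them.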